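Swapping a bulky carbinol for fluorine on the triazine aryl ring

The compounds below may be only part of what the source reports. "The series", "measured", "known", "first", "only" and "open" are said of these compounds alone.

Compound 1 `CC1(C)N=C(N)N=C(N)N1c1cccc(C(O)c2ccccc2)c1` is the weakest of the three compounds measured, giving 4.17 in a functional assay on L5178Y cells (Mus musculus); on this read-out lower numbers stand for lower potency and higher numbers for higher potency (the scale is a negative logarithm). Compound 2 `CCCCCCCCCCCCCOc1cccc(N2C(N)=NC(N)=NC2(C)C)c1` gives 6.52 and compound 3 `CCCCCCCCCCCCCCOc1cccc(N2C(N)=NC(N)=NC2(C)C)c1` gives 6.49, both far higher. Going by the values given here, the one single-point step known, a number 0.03 log units lower from compound 2 to compound 3 (within the scatter), concerns only the length of the alkoxy chain and says nothing about the aryl substituent. Compound 4 `CC1(C)N=C(N)N=C(N)N1c1cccc(F)c1` differs from compound 1 as follows: fluoro in place of hydroxy(phenyl)methyl on an aromatic carbon. Among the compounds with values here, no measured pair bears on this exchange, so the expectation rests on compound 1 alone and carries wide uncertainty. Compound 4 is estimated at 4.6, within 3.8 to 5.6, which would mean an expected step of a number 0.43 log units higher from compound 1 to compound 4 (beyond the scatter).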

Compound 4, logarithm of the reciprocal of the active concentration, log(1/C): 5.24
Compound 4: the middle estimate sits 0.64 log units below what was measured, within the range that was stated.
By their numbers in this assay, from the lowest: compound 1; then compound 4; then compounds 3 and 2 (each within the scatter of the next).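

In this assay, going by these compounds alone, the step of a number 1.07 log units higher from compound 1 to compound 4 (beyond the scatter) is the first reading at this aromatic carbon, as the earlier step concerned only the alkoxy chain. It shows that hydroxy(phenyl)methyl, with its aromatic ring and hydroxyl, is not required here for activity, and that a single fluorine atom does better. No measurement at hand accounts for the size of this step.

As far as these compounds go, whether the gain comes from fluoro itself or simply from losing hydroxy(phenyl)methyl stays open. Chloro, methyl or methoxy at this place would help to separate the two.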